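From compound 1 to compound 3: a pendant aryl change

The compounds below may be only part of what the source reports. "The series", "measured", "known", "first", "only" and "open" are said of these compounds alone.

compound 1 `O=S(=O)(c1cc(Cl)cc(Cl)c1)c1cnc2cc(F)ccc2c1-c1cccc(F)c1`: 35 nM
compound 2 `O=S(=O)(c1cc(F)cc(F)c1)c1cnc2cc(F)ccc2c1-c1cccc(F)c1`: 74 nM

In a functional assay on cells for negative allosteric modulation of metabotropic glutamate receptor 5 (Homo sapiens), read by fluorescence and calcium flux, with a stated time of 20 min (a lower number here means a stronger inhibitor, a higher number a weaker inhibitor), compound 1 gives 35 nM, the lowest of the two numbers. Compound 2 gives 74 nM, and the change from compound 1 to compound 2 is a 2.1-fold higher number from compound 1 to compound 2 (0.33 log units; beyond the scatter), a change at the sulfonyl sulfur. Compound 3 `O=S(=O)(c1cc(Cl)cc(Cl)c1)c1cnc2cc(F)ccc2c1-c1ccc(Cl)cc1` differs from compound 1 elsewhere: 4-chlorophenyl in place of 3-fluorophenyl on an aromatic carbon. For the measured compounds named here, no measured step touches this position, so the one measured step offers no direct guide. Compound 3 is therefore expected to stay close to compound 1, with a step of a 1.4-fold higher number from compound 1 to compound 3 (0.15 log units; within the scatter) and an estimate of 50 nM, within a range of 15 nM to 170 nM.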

Compound 3, half-maximal inhibitory concentration: 94 nM
Compound 3: the middle estimate sits 1.9-fold (0.27 log units) below what was measured, within the range that was stated.
By their numbers in this assay, from the lowest: compound 1; then compounds 2 and 3 (each within the scatter of the next).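

In this assay 4-chlorophenyl in place of 3-fluorophenyl on this aromatic carbon gives a 2.7-fold higher number from compound 1 to compound 3 (0.43 log units; beyond the scatter) and so shows that this position, which the step at the sulfonyl sulfur left untouched, also responds to change. The change alters both the halogen and where it sits on the phenyl ring, and this single step cannot separate the two. Nothing available explains the step. Still open, as far as these compounds go, is whether 3-chlorophenyl or 4-fluorophenyl would read closer to compound 1 or to compound 3. Also open, from the compounds shown here alone, is how a methoxy group or an amine on that phenyl ring would read.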